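Swapping the Aryl Group on a Nucleoside Core

The source may hold more compounds than are shown below. What is called first, only, known or untested is meant among the compounds shown, and "the series" means these compounds.

Measured so far:
compound 1, `Cc1ccc(-c2ncnc3c2ncn3C2O[C@H](CO)[C@@H](O)[C@H]2O)cc1`: 1500 nM
compound 2, `CC(=O)OC[C@H]1O[C@@H](n2cnc3c(-c4ccc(F)c(F)c4)ncnc32)[C@H](OC(C)=O)[C@@H]1OC(C)=O`: 8300 nM

In a functional assay on CCRF-CEM cells (Homo sapiens) for inhibition (on this read-out lower numbers stand for stronger inhibition and higher numbers for weaker inhibition), compound 1 gives 1500 nM, the lowest of the two numbers available. Compound 2 differs from compound 1 in several places. In this assay compound 2 gives 8300 nM. Its value is higher than that of compound 1 by a step beyond the usual scatter, so compound 1 is the stronger inhibitor of the pair.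

Compound 3, `COc1cccc(-c2ncnc3c2ncn3C2O[C@H](CO)[C@@H](O)[C@H]2O)c1`, has not yet been measured. Compared with compound 1, the change is 3-methoxyphenyl in place of 4-methylphenyl on an aromatic carbon. Only the group on that aromatic carbon changes; the shared core and its sugar part stay the same. For the measured compounds named here, no measured pair shows this exact change, so the expected step from compound 1 to compound 3 is uncertain. A small weakening is expected, a 1.7-fold higher number from compound 1 to compound 3 (0.22 log units; within the scatter), at or near the edge of the scatter. Compound 3 is therefore estimated at 2500 nM, within a range from 800 nM to 8000 nM.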

Compound 3, half-maximal inhibitory concentration: 4800 nM
Compound 3: the middle estimate sits 1.9-fold (0.28 log units) below what was measured; the measured number falls inside the stated range.
By their numbers in this assay, from the lowest: compound 1; then compounds 3 and 2 (each within the scatter of the next).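

Compound 1 and compound 3 share the core and its sugar part, so this pair isolates the aryl group on the aromatic carbon next to the ring nitrogen, which the several differences between compound 1 and compound 2 could not do. In this assay, 3-methoxyphenyl in place of 4-methylphenyl gives a 3.2-fold higher number from compound 1 to compound 3 (0.51 log units; beyond the scatter), a modest weakening beyond the scatter, so the read-out is sensitive to the choice of aryl group at this position. No available measurement accounts for this step.

The change replaces methyl with methoxy and also alters where the group sits on the phenyl ring, and the compounds shown do not separate these two differences. On these data alone, it also remains open how a phenyl ring carrying an amine or a carboxylic acid would read in this assay.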